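The compounds below may be only part of what the source reports. "The series", "measured", "known", "first", "only" and "open" are said of these compounds alone.

Within the data shown here, compound 2 `CCC(NC(=O)C(CC(C)C)NC(=O)OCc1ccccc1)C(=O)C(=O)NCCCc1ccccc1` gives 800 nM in an assay on isolated protein for inhibition of Calpain-1 catalytic subunit (Homo sapiens) (a higher number here means a weaker inhibitor, a lower number a stronger inhibitor), one of only two numbers so far, and compound 1 `CCC(NC(=O)C(CC(C)C)NC(=O)OCc1ccccc1)C(=O)C(=O)NCCCCCO` gives 500 nM, the two lying within the usual scatter of each other, as a 1.6-fold higher number from compound 1 to compound 2 (0.20 log units; within the scatter) shows. Compound 3 `CCC(NC(=O)C(CC(C)C)NC(=O)OCc1ccccc1)C(=O)C(=O)NCc1cc(OC)cc(OC)c1` carries 3,5-dimethoxyphenyl in place of phenethyl on a saturated chain carbon bound to an amide-type nitrogen. Among the measured compounds shown here, the single earlier step in this tail, phenyl in place of 2-hydroxyethyl, barely moved this assay, so a further exchange of aromatic tail is expected to move it little as well. For compound 3 the estimate is 800 nM, expected to fall between 300 nM and 2500 nM, which means an expected step of no change at the digits printed from compound 2 to compound 3 (within the scatter).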

Compound 3, inhibition constant: 2300 nM
Beside the measured number, compound 3's estimate is 2.9-fold (0.46 log units) below it; low and high end bracket the measured number.
By their numbers in this assay, from the lowest: compounds 1 and 2 (each within the scatter of the next); then compound 3.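

In this assay, among these compounds, this position is not indifferent to the group it carries: 3,5-dimethoxyphenyl in place of phenethyl gives a 2.9-fold higher number from compound 2 to compound 3 (0.46 log units; beyond the scatter) and so produces the first step here beyond the scatter. Set against the 4-hydroxybutyl tail, the same group gives a 4.6-fold higher number from compound 1 to compound 3 (0.66 log units; beyond the scatter) and leaves the new compound the weakest of the three. Nothing measured here explains this loss.

The change from 3-phenylpropyl to 3,5-dimethoxybenzyl alters the chain and the ring together, so a plain benzyl tail would be needed to separate the two. On these data alone, how a tail ending in an amine or a carboxylic acid would behave also remains open.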